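Removing the cyclopentyl from a sulfonamide nitrogen

This account rests on a few compounds, and the source may have more. Where it says the series, first, only, none or still open, it means among the compounds named here.

Measured compounds in a functional assay on HeLa cells (Homo sapiens) for antiproliferative activity, read by CCK-8 assay, with a stated time of 72 h; a lower number here means a stronger inhibitor of growth, a higher number a weaker inhibitor of growth:
compound 1 `CCCNS(=O)(=O)c1ccc(Nc2ncc3c(n2)N(C2CCCC2)[C@H](CC)C(=O)N3C)cc1` gives 459 nM
compound 2 `CC[C@@H]1C(=O)N(C)c2cnc(Nc3ccc(S(=O)(=O)NCCO)cc3)nc2N1C1CCCC1` gives 459 nM
compound 3 `CC[C@@H]1C(=O)N(C)c2cnc(Nc3ccc(S(=O)(=O)NC4CCCC4)cc3)nc2N1C1CCCC1` gives 609 nM

The three measured compounds share one core and differ only in the group on the sulfonamide nitrogen. Compound 3 carries the highest of the three numbers, but its steps to both neighbours lie within the scatter: a 1.3-fold higher number from compound 1 to compound 3 (0.12 log units; within the scatter) and a 1.3-fold higher number from compound 2 to compound 3 (0.12 log units; within the scatter). Between compound 1 and compound 2 there is likewise no change at the digits printed from compound 1 to compound 2 (within the scatter). Taken together, propyl, 2-hydroxyethyl and cyclopentyl on that nitrogen give numbers that cannot be told apart.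

Compound 4 `CC[C@@H]1C(=O)N(C)c2cnc(Nc3ccc(S(N)(=O)=O)cc3)nc2N1C1CCCC1` is not yet measured. The change from compound 3 reads (hydrogen in place of cyclopentyl on a sulfonamide nitrogen). For the measured compounds named here, the two steps that bear on it are those in which cyclopentyl arrived on the sulfonamide nitrogen, and both were within the scatter; no measured step removes every substituent from that nitrogen, so the sulfamoyl case is not directly covered. On the evidence that the three substituents already tried did not shift the number, compound 4 is expected to give a value close to that of compound 3, with a step of a 1.1-fold lower number from compound 3 to compound 4 (0.04 log units; within the scatter) expected to stay within the scatter. The estimate for compound 4 is 550 nM, with a range from 200 nM to 1500 nM.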

Compound 4, concentration for 50% growth inhibition: 317 nM
Beside the measured number, compound 4's estimate is 1.7-fold (0.24 log units) above it; low and high end bracket the measured number.
By their numbers in this assay, from the lowest: compounds 4, 1, 2 and 3 (each within the scatter of the next).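

For the compounds shown here, with compound 4, the cyclopentyl is gone and the sulfonamide nitrogen has sulfonyl sulfur and hydrogen as its neighbours, a case the earlier compounds did not cover, and in this assay it cannot be told apart from any of them. Hydrogen in place of cyclopentyl gives a 1.9-fold lower number from compound 3 to compound 4 (0.28 log units; within the scatter) and hydrogen in place of 2-hydroxyethyl gives a 1.4-fold lower number from compound 2 to compound 4 (0.16 log units; within the scatter) while hydrogen in place of propyl gives a 1.4-fold lower number from compound 1 to compound 4 (0.16 log units; within the scatter) and so, across these four compounds, a substituent on that nitrogen is not needed to keep the number where it stands, and none of the three tried moves it beyond the scatter. Nothing measured here offers an explanation for this flat response.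

The compounds shown leave open whether a group of another kind on that nitrogen, such as a chain ending in an amine, a carboxylic acid, a phenyl ring or a longer chain, would move the number beyond the scatter. On these data alone, all four also keep the sulfonyl, so the effect of replacing the whole sulfamoyl, for instance with a carboxamide, remains open as well.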